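Naphthalene to Difluorophenyl: Expected Effect on Solubility

The source may report more compounds than this note shows. Statements on the series, on what has been measured and on what is new or still open speak of the compounds shown alone.

Compound 1 `CC(C)(C)C(=O)N1Cc2c(NC(=O)C3CCNCC3)n[nH]c2C1(C)C` gives > 225000 nM in a physicochemical assay for solubility, at pH 7 (on this read-out lower numbers stand for lower solubility and higher numbers for higher solubility), which is a limit of the assay and not a number.
Compound 2 `CN1CCC(C(=O)N2Cc3c(NC(=O)c4ccc5ccccc5c4)n[nH]c3C2(C)C)CC1` gives 219000 nM in this assay.

Among the measured compounds shown here, compound 2 thus stands as the only plain number so far; the other value shown is a limit (the limit of > 225000 nM in this assay, at which 1 of the 2 values shown sits). Compound 3 `CN1CCC(C(=O)N2Cc3c(NC(=O)c4ccc(F)c(F)c4)n[nH]c3C2(C)C)CC1` is not yet measured in this assay; it differs from compound 2 by 3,4-difluorophenyl in place of naphthalen-2-yl on a carbonyl carbon. For the measured compounds named here, no step between measured compounds exists to lean on, so the expectation is cautious: a small rise, perhaps within the scatter, possibly reaching the limit. Compound 3 is estimated at 250000 nM, between 150000 nM and 450000 nM. That expectation amounts to a step of a 1.1-fold higher number from compound 2 to compound 3 (0.06 log units; within the scatter).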

Compound 3, solubility: > 225000 nM
Compound 3 ended at the assay's limit; the forecaster's own chance of this, stated with the estimate: 50%; the middle value does not contradict the limit.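

Putting 3,4-difluorophenyl in place of naphthalen-2-yl on a carbonyl carbon gives an at least 1.0-fold higher number from compound 2 to compound 3 (0.01 log units; that floor lies within the scatter) in this assay, so the number does not fall at this position when two aromatic rings give way to one. For compound 3, > 225000 nM is a limit of the assay and not a number. The size of the step therefore cannot be read beyond its floor, and the series now crowds against that limit: the limit of > 225000 nM in this assay, at which 2 of the 3 values shown sit.

As far as these compounds go, how far compound 3 lies past the limit stays open. Also open, from the compounds shown here alone, is whether an amine or a carboxylic acid in place of 3,4-difluorophenyl would give a readable number.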